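Dropping One Fluorine: What to Expect for Compound 4

The source may hold more compounds than are shown below. What is called first, only, known or untested is meant among the compounds shown, and "the series" means these compounds.

Three compounds sharing one core were tested in an assay on NIH3T3 cells for inhibition of Sonic hedgehog protein (Mus musculus), read by a luciferase reporter, with a stated time of 48 h; on this read-out higher numbers stand for weaker inhibition and lower numbers for stronger inhibition. Compound 1 `Cc1cnc(Nc2ccc(C(=O)Nc3c(C)cccc3C)cc2)nc1-c1ccc(OC(F)(F)F)cc1` gives 1.3 nM. Compound 2 `Cc1cnc(Nc2ccc(C(=O)Nc3c(C)cccc3C)cc2)nc1-c1ccccc1OC(F)(F)F` reaches only a limit, > 500 nM (the limit of > 500 nM in this assay, at which 1 of the 3 values shown sits). Compound 3 `Cc1cnc(Nc2ccc(C(=O)Nc3c(C)cccc3C)cc2)nc1-c1ccc(F)cc1` gives 2.2 nM; the step of a 1.7-fold higher number from compound 1 to compound 3 (0.23 log units; within the scatter) is within the scatter, so compound 3 and compound 1 stand together, while an at least 380-fold higher number from compound 1 to compound 2 (2.58 log units; beyond the scatter) and an at least 220-fold lower number from compound 2 to compound 3 (2.35 log units; beyond the scatter) are large. Compound 4 `Cc1cnc(Nc2ccc(C(=O)Nc3c(C)cccc3C)cc2)nc1-c1ccccc1` is not yet measured; it differs from compound 3 by hydrogen in place of fluoro on an aromatic carbon. The step that bears on this change is a 1.7-fold higher number from compound 1 to compound 3 (0.23 log units; within the scatter), where exchanging one group for another on the same carbon moved the number only within the scatter. A small step or none is therefore expected in this assay. Compound 4 is estimated at 3.5 nM (range 1.2 nM to 10 nM), an expected step of a 1.6-fold higher number from compound 3 to compound 4 (0.20 log units; within the scatter).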

Compound 4, half-maximal inhibitory concentration: 1.3 nM
Compound 4: middle estimate off by 2.7-fold (0.43 log units), on the high side, and the stated range covers the measured number.
By their numbers in this assay, from the lowest: compounds 1, 4 and 3 (each within the scatter of the next). At a limit, above all of these: compound 2.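

With a 1.7-fold lower number from compound 3 to compound 4 (0.23 log units; within the scatter) and no change at the digits printed from compound 1 to compound 4 (within the scatter), the carbon para to a large group needs neither fluoro nor trifluoromethoxy to hold its number in this assay: hydrogen alone serves as well. The step to the bare ring stays large, an at least 380-fold lower number from compound 2 to compound 4 (2.58 log units; beyond the scatter), so the loss travels with the 2-(trifluoromethoxy)phenyl group, not with any missing group on this carbon. That step rests on a limit for compound 2: the limit of > 500 nM in this assay, at which 1 of the 4 values shown sits.

On these data alone, whether an amine or a carboxylic acid on this carbon would hold the number as well stays open.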